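This account rests on a few compounds, and the source may have more. Where it says the series, first, only, none or still open, it means among the compounds named here.

In a functional assay on MCF7 cells (Homo sapiens) for antiproliferative activity, read by MTT assay, with a stated time of 72 h (on this read-out lower numbers stand for stronger inhibition and higher numbers for weaker inhibition), compound 1 `CCCCCC#Cc1cn(CCC(COC(C)=O)COC(C)=O)c(=O)n(C(=O)c2ccccc2)c1=O` gives 62200 nM. Compound 2 `CCCCCCCCC#Cc1cn(CCC(COC(C)=O)COC(C)=O)c(=O)n(C(=O)c2ccccc2)c1=O` carries propyl in place of hydrogen on a saturated chain carbon, five bonds along the chain from a triple-bonded carbon and gives 28900 nM in this assay, so that the step of a 2.2-fold lower number from compound 1 to compound 2 (0.33 log units; beyond the scatter) is a modest one. Compound 3 `CCCCCC#Cc1cn(CCC(CO)CO)c(=O)[nH]c1=O` has a core that differs from that of compound 1 in a way not broken down here. In this assay compound 3 gives 37800 nM; its value and those of compound 1 and compound 2 all lie within the scatter of one another. Compound 4 `CCCCCCCCC#Cc1cn(CCC(CO)CO)c(=O)[nH]c1=O` differs from compound 3 by propyl in place of hydrogen on a saturated chain carbon, five bonds along the chain from a triple-bonded carbon, the same change, at the same place, as that from compound 1 to compound 2. The earlier step of a 2.2-fold lower number from compound 1 to compound 2 (0.33 log units; beyond the scatter) was modest. On that basis a similar step is expected here, a 2.1-fold lower number from compound 3 to compound 4 (0.32 log units; beyond the scatter). Compound 4 is therefore estimated to give 18000 nM in this assay, with an expected range from 7000 nM to 45000 nM.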

Compound 4, half-maximal inhibitory concentration: 40300 nM
For compound 4 the middle estimate is 2.2-fold (0.35 log units) below the measured one; the measured number falls inside the stated range.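

In this assay the change gives a 1.1-fold higher number from compound 3 to compound 4 (0.03 log units; within the scatter). Set beside the earlier step on the core of compound 1, the two steps cannot be told apart: the same change on two cores in this assay, a 2.2-fold lower number (0.33 log units; beyond the scatter) from compound 1 to compound 2 and a 1.1-fold higher number (0.03 log units; within the scatter) from compound 3 to compound 4, 2.3-fold (0.36 log units) apart, within the scatter of two such steps. This does not show that the change carries over from one core to the other, nor that it fails to, since one pair of steps of this size cannot settle either reading.

From the compounds shown here alone, it remains open whether a longer chain, an amine or a carboxylic acid in place of the propyl would move the number on either core. Also open, going by these compounds, is what the acetyl and benzoyl groups that set compound 1 apart from compound 3 each contribute on their own.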